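Isopropylsulfanyl in Place of Methylsulfanyl: Tolerance Expected to Hold

The source may report more compounds than this note shows. Statements on the series, on what has been measured and on what is new or still open speak of the compounds shown alone.

Compound 1 `Fc1ccc(-c2nn3c(NC4CCCC4)cc(NC4CCCC4)cc3c2-c2ccnc(NC3CCCC3)n2)cc1` and compound 2 `CSc1cc(NC2CCCC2)cc2c(-c3ccnc(NC4CCCC4)n3)c(-c3ccc(F)cc3)nn12` share one core and differ at a single aromatic carbon, where compound 2 carries methylsulfanyl instead of cyclopentylamino. In an ADME assay on Vero cells (Chlorocebus sabaeus) for cytotoxicity (a higher number here means that more compound is tolerated, a lower number that less compound is tolerated), compound 1 gives > 40000 nM, which is a limit of the assay and not a number. In this assay compound 2 gives > 40000 nM, again a limit of the assay. The step that the two limits leave unreadable from compound 1 to compound 2 is therefore unreadable, and compound 2 stands at the limit of > 40000 nM in this assay, at which 2 of the 2 values shown sit. Compound 3 `CC(C)Sc1cc(NC2CCCC2)cc2c(-c3ccnc(NC4CCCC4)n3)c(-c3ccc(F)cc3)nn12` carries isopropyl in place of methyl on a sulfur. Among the compounds with values here, the only measured step that bears on this change is the unreadable one, so it gives no direction and no size; with both measured values resting at the limit, compound 3 is expected to rest there too, so that the expected step of a number no higher from compound 2 to compound 3 (the limit leaves the size open) is none beyond the scatter. The estimate for compound 3 in this assay is 40000 nM, ranging between 20000 nM and 80000 nM.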

Compound 3, half-maximal cytotoxic concentration: > 40000 nM
Compound 3 ended at the assay's limit (the forecaster's own chance of this, stated with the estimate: 85%); the middle value sits exactly at the limit.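

No step can be read among compound 1, compound 2 and compound 3 in this assay, since each result is a limit of the assay and not a number: the limit of > 40000 nM in this assay, at which 3 of the 3 values shown sit.

The compounds shown leave open how far tolerance differs among them, and whether any change at this aromatic carbon or on this sulfur alters it.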